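The source may hold more compounds than are shown below. What is called first, only, known or untested is meant among the compounds shown, and "the series" means these compounds.

Measured so far in a functional assay on A549 cells (Homo sapiens) for antiproliferative activity, read by MTT assay, with a stated time of 72 h; a higher number here means a weaker inhibitor, a lower number a stronger inhibitor:
compound 1 `O=C(N/N=C/c1ccccc1)Nc1ccc(Oc2ccnc3[nH]ccc23)c(F)c1` gives 2500 nM
compound 2 `O=C(N/N=C/c1ccc(Br)cc1)Nc1ccc(Oc2ccnc3[nH]ccc23)c(F)c1` gives 820 nM
compound 3 `O=C(N/N=C/c1ccccc1)Nc1ccc(Oc2ccnc3[nH]ccc23)cc1` gives 17200 nM

Compound 3 has the highest number of the three, and a 6.9-fold higher number from compound 1 to compound 3 (0.84 log units; beyond the scatter) separates it from its fluoro counterpart. Compound 2, at 820 nM, lies further from it still.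

The next compound to be tested is compound 4 `O=C(N/N=C/c1ccc(Br)cc1)Nc1ccc(Oc2ccnc3[nH]ccc23)cc1`. It differs from compound 3 by bromo in place of hydrogen on an aromatic carbon, para to a large group, or phenyl to 4-bromophenyl.

The same change has been measured once, in the fluoro series, and there it gave a 3.0-fold lower number from compound 1 to compound 2 (0.48 log units; beyond the scatter). Among the compounds with values here, this is the only direct precedent. Within the data shown here, the step of a 6.9-fold higher number from compound 1 to compound 3 (0.84 log units; beyond the scatter) concerns a different change and shows only that compound 3 starts from a higher number. Whether the bromo step carries over to the series without fluoro is not yet known, and a single pair cannot settle it.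

A step of similar, modest size towards a lower number is therefore expected in this assay. The estimate amounts to a 3.0-fold lower number from compound 3 to compound 4 (0.48 log units; beyond the scatter) in expectation.

For compound 4 the estimated value is 5700 nM, with an expected range from 2500 nM to 13000 nM as the estimate's bounds.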

Compound 4, half-maximal inhibitory concentration: 640 nM
The estimate for compound 4 lay 8.9-fold (0.95 log units) above the measured number; measured number below the stated range.
By their numbers in this assay, from the lowest: compounds 4 and 2 (each within the scatter of the next); then compound 1; then compound 3.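

In this assay, bromo in place of hydrogen, para to a large group, gives a 27-fold lower number from compound 3 to compound 4 (1.43 log units; beyond the scatter), so the phenyl to 4-bromophenyl change has no fixed size in this series and depends on the rest of the molecule: the same change on two cores in this assay, a 3.0-fold lower number (0.48 log units; beyond the scatter) from compound 1 to compound 2 and a 27-fold lower number (1.43 log units; beyond the scatter) from compound 3 to compound 4, 8.8-fold (0.95 log units) apart, beyond the scatter of two such steps

The fluoro change depends on its context in the same way, since with 4-bromophenyl in place, hydrogen in place of fluoro gives a 1.3-fold lower number from compound 2 to compound 4 (0.11 log units; within the scatter), which is within the scatter, unlike the same change with plain phenyl: the same change on two cores in this assay, a 6.9-fold higher number (0.84 log units; beyond the scatter) from compound 1 to compound 3 and a 1.3-fold lower number (0.11 log units; within the scatter) from compound 2 to compound 4, 8.8-fold (0.95 log units) apart, beyond the scatter of two such steps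

Across these four compounds the two changes therefore do not add up: bromo or fluoro alone brings the number down from that of compound 3, whereas fluoro gives no step beyond the scatter once bromo is present.

As far as these compounds go, it remains open whether this dependence is particular to bromo, or whether chloro, methoxy, an amine or a carboxylic acid at the same place on the phenyl would also remove the difference between the fluoro and non-fluoro cores. Four compounds in a single cell assay also do not show why the two changes interact.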